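The source may hold more compounds than are shown below. What is called first, only, known or untested is meant among the compounds shown, and "the series" means these compounds.

Compound 1 `Oc1cc(F)ccc1CNc1ccc(C2CCCCC2)cc1`: "not active" (no number reported) in a functional assay on Jurkat cells (Homo sapiens) for activation, with a stated time of 24 h; on this read-out lower numbers stand for an effect already at smaller amounts and higher numbers for an effect only at larger amounts of compound.
Compound 2 `Oc1ccccc1CNc1ccc(-c2ccc(Cl)cc2)cc1`: 2390 nM in this assay.

Compound 2 stands alone with a number; the entry for compound 1 carries no number at all. Compound 3 `Oc1ccc(-c2ccc(NCc3ccccc3O)cc2)cc1` differs from compound 2 by hydroxy in place of chloro on an aromatic carbon. For the measured compounds named here, no step between two measured compounds is at hand to show what such a change does here, so the size is a guess. A modest loss is expected, a step of a 1.9-fold higher number from compound 2 to compound 3 (0.27 log units; within the scatter) in this assay, somewhat beyond the scatter. Compound 3 is estimated at 4500 nM, within a range from 1000 nM to 20000 nM.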

Compound 3, half-maximal effective concentration: "not active" (no number reported)
No number was reported for compound 3; the estimate stays without a comparison.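

For the compounds shown here, compound 3 is reported as "not active" without a number, so no step from compound 2 to compound 3 can be read. How far the change from 4-chlorophenyl to 4-hydroxyphenyl shifts the result in this assay stays open, and nothing shown here bears on the reason.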